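This account rests on a few compounds, and the source may have more. Where it says the series, first, only, none or still open, it means among the compounds named here.

Measured so far:
compound 1, `CCC(=O)N1CC[C@H](Oc2ncnc3c2nc(-c2cnc(C)nc2)n3CC)C1`, with 2.7 L/kg;
compound 2, `CCn1c(-c2cnc(C)nc2)nc2c(N[C@H]3CCN(C(=O)C4CC4)C3)ncnc21`, with 1.8 L/kg.

In an ADME assay (Canis lupus familiaris, strain Beagle) for pharmacokinetics (on this read-out lower numbers stand for narrower distribution and higher numbers for wider distribution into tissues), compound 1 stands at 2.7 L/kg. Compound 2, in this assay, stands at 1.8 L/kg, and the two numbers lie within the usual scatter of each other, so nothing separates them beyond what repeated measurement would give. Compound 3, `CCn1c(-c2cnc(C)nc2)nc2c(O[C@H]3CCN(C(=O)[C@H]4C[C@@H](OC)C4)C3)ncnc21`, is the next compound to be measured in this assay. Compared with compound 1 the change is 3-methoxycyclobutyl in place of ethyl on a carbonyl carbon. For the measured compounds named here, no step between measured compounds shows what such a change does to the distribution volume, so the expectation rests on compound 1 alone, with a range wide enough to cover a moderate movement either way. Compound 3 is expected to stay close to compound 1, the step of a 1.1-fold lower number from compound 1 to compound 3 (0.05 log units; within the scatter) being no larger than the scatter. Compound 3 is estimated at 2.4 L/kg, with a range from 1.3 L/kg to 4.5 L/kg.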

Compound 3, volume of distribution: 0.9 L/kg
Estimate against measurement, compound 3: 2.7-fold (0.43 log units) above; measured number below the stated range.
By their numbers in this assay, from the lowest: compounds 3, 2 and 1 (each within the scatter of the next, the first and the last beyond it).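

In this assay, 3-methoxycyclobutyl in place of ethyl on a carbonyl carbon gives a 3.0-fold lower number from compound 1 to compound 3 (0.48 log units; beyond the scatter), the first step read at this position. It shows that the group on this carbonyl carbon, whose other neighbour is an amide-type nitrogen in a ring, can move the distribution volume by more than repeated measurement would, and that here the larger group goes with the lower number. Nothing available explains this step.

The compounds shown leave open whether the four-membered ring or the methoxy carries the step, which a plain cyclobutyl or a 2-methoxyethyl group on the same carbonyl carbon would help to separate. They also leave open whether the other stereoisomer of the 3-methoxycyclobutyl group would give a step of the same size.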